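Methyl Enters a Series That Shows No Cytotoxicity

The source may report more compounds than this note shows. Statements on the series, on what has been measured and on what is new or still open speak of the compounds shown alone.

Three amides sharing one core were tested in an ADME assay on BJ cells (Homo sapiens) for cytotoxicity, with a stated time of 72 h; on this read-out lower numbers stand for an effect already at smaller amounts and higher numbers for an effect only at larger amounts of compound. Compound 1 `COc1cc(Cl)c(C(=O)Nc2cccc(-c3nc4ccccc4s3)c2)cc1[N+](=O)[O-]` gives > 25000 nM in this assay, which is a limit of the measurement rather than a number. Compound 2 `O=C(Nc1cccc(-c2nc3ccccc3s2)c1)c1cc([N+](=O)[O-])ccc1Cl` likewise reaches only a limit, > 27000 nM, in this assay. Compound 3 `O=C(Nc1cccc(-c2nc3ccccc3o2)c1)c1cc([N+](=O)[O-])ccc1Cl` also stops at a limit, > 25000 nM, in this assay. The step that the two limits leave unreadable from compound 1 to compound 2 is hydrogen in place of methoxy on an aromatic carbon, and the step that the two limits leave unreadable from compound 2 to compound 3 is 1,3-benzoxazol-2-yl in place of 1,3-benzothiazol-2-yl on an aromatic carbon; neither can be sized. The two limits involved are the limit of > 25000 nM in this assay, at which 2 of the 3 values shown sit, and (the limit of > 27000 nM in this assay, at which 1 of the 3 values shown sits). Compound 2 therefore stands where every value shown stands: at a limit, with no number to place it against the others.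

Compound 4 `Cc1c(NC(=O)c2cc([N+](=O)[O-])ccc2Cl)cccc1-c1nc2ccccc2s1` differs from compound 2 by methyl in place of hydrogen on an aromatic carbon. Within the data shown here, no measured step bears directly on this change, and the two known steps are unreadable, so nothing points to an effect beyond the scatter in this assay. Compound 4 is expected to sit again at or past the limit, with a number no higher from compound 2 to compound 4 (the limit leaves the size open) estimated as no step beyond the scatter. For compound 4 the estimate in this assay is 27000 nM, within 12000 nM to 60000 nM.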

Compound 4, half-maximal effective concentration: > 25000 nM
Compound 4: only a limit was reported; the forecaster's own chance of this, stated with the estimate: 80%; the middle value does not contradict the limit.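

In this assay compound 4 gives > 25000 nM, which is a limit and not a number. Compound 2 also stands at a limit, so no step can be read between compound 2 and compound 4. The compounds shown leave open at what amount, if any, compounds 1 to 4 would show an effect in this assay.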